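Methyl in place of nitro: working notes

The compounds below may be only part of what the source reports. "The series", "measured", "known", "first", "only" and "open" are said of these compounds alone.

Compound 1 `O=[N+]([O-])c1cccc(Nc2ncc3c(n2)CCCC3)c1`: 3500 nM
Compound 2 `Cc1ccccc1Nc1ncc2c(n1)CCCC2`: > 10000 nM, a limit of the assay

Within the data shown here, in a functional assay on MV4-11 cells (Homo sapiens) for inhibition, read by resazurin assay, with a stated time of 72 h (a higher number here means a weaker inhibitor of growth, a lower number a stronger inhibitor of growth), compound 1 gives 3500 nM, the only actual number among the values so far. Compound 2 reads > 10000 nM, which is a limit and not a number.

Compound 3 `Cc1cccc(Nc2ncc3c(n2)CCCC3)c1` keeps the core of compound 1 and differs in one place: methyl in place of nitro on an aromatic carbon. Among the measured compounds shown here, no measured pair of compounds shows the size of such a change. A modest weakening in this assay is expected, though a result within the scatter would be no surprise. The expected step is a 1.7-fold higher number from compound 1 to compound 3 (0.23 log units; within the scatter). For compound 3 the estimated value is 6000 nM. The estimated range for compound 3 runs from 2000 nM to 16000 nM.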

Compound 3, concentration for 50% growth inhibition: 3290 nM
The estimate for compound 3 lay 1.8-fold (0.26 log units) above the measured number, within the range that was stated.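

In this assay, methyl in place of nitro on an aromatic carbon, meta to a large group, gives a 1.1-fold lower number from compound 1 to compound 3 (0.03 log units; within the scatter), the first measured size for this change in the series. At this place on the shared core, nitro is therefore not required for the growth inhibition read here, and this assay does not separate the two groups. Compound 2 gives no further comparison, since its reading is a limit and not a number, and any step to it cannot be read: the limit of > 10000 nM in this assay, at which 1 of the 3 values shown sits.

As far as these compounds go, it remains open whether an amine, a carboxylic acid or a longer chain at this same place would move the number beyond the scatter. From the compounds shown here alone, whether methyl and nitro would also match on a different core remains open too.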